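This account rests on a few compounds, and the source may have more. Where it says the series, first, only, none or still open, it means among the compounds named here.

Compound 1 `CC1(C)CCC(CN2CCN(c3ccc(C(=O)NS(=O)(=O)c4ccc(NCC5CCOCC5)c([N+](=O)[O-])c4)c(Oc4cnc5[nH]ccc5c4)c3)CC2)=C(c2ccc(Cl)cc2C(F)(F)F)C1` gives 0.86 nM in an assay on isolated protein for displacement of a labelled ligand from Apoptosis regulator Bcl-2 (Homo sapiens), with a stated time of 15 min; a higher number here means a weaker inhibitor, a lower number a stronger inhibitor. Compound 2 `CC1(C)CCC(CN2CCN(c3ccc(C(=O)NS(=O)(=O)c4ccc(NCC5CCOCC5)c([N+](=O)[O-])c4)c(Oc4cnc5[nH]ccc5c4)c3)CC2)=C(c2ccccc2C(F)(F)F)C1` gives 1.7 nM in this assay.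

In this assay compound 2 stands highest of the two numbers, with compound 1 nearest: the step of a 2.0-fold higher number from compound 1 to compound 2 (0.30 log units; within the scatter) lies within the scatter. Compound 3 `CC1(C)CCC(CN2CCN(c3ccc(C(=O)NS(=O)(=O)c4ccc(NCC5CCOCC5)c([N+](=O)[O-])c4)c(Oc4cnc5[nH]ccc5c4)c3)CC2)=C(c2ccc(C(F)(F)F)c(Cl)c2)C1` differs from compound 2 by 3-chloro-4-(trifluoromethyl)phenyl in place of 2-(trifluoromethyl)phenyl on a double-bonded ring carbon. Going by the values given here, the only step with a bearing is a 2.0-fold higher number from compound 1 to compound 2 (0.30 log units; within the scatter), where the loss of a chloro changed little; compound 3 restores a chloro, but not at the same position, so no step beyond the scatter is expected. Compound 3 is estimated at 1.3 nM (range 0.4 nM to 4 nM), an expected step of a 1.3-fold lower number from compound 2 to compound 3 (0.12 log units; within the scatter).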

Compound 3, half-maximal inhibitory concentration: 0.8 nM
Beside the measured number, compound 3's estimate is 1.6-fold (0.21 log units) above it; the measured number falls inside the stated range.
By their numbers in this assay, from the lowest: compounds 3, 1 and 2 (each within the scatter of the next, the first and the last beyond it).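

In this assay, going by these compounds alone, the change to 3-chloro-4-(trifluoromethyl)phenyl gives a 2.1-fold lower number from compound 2 to compound 3 (0.33 log units; beyond the scatter) and is the only step at this position that lies beyond the scatter, though modestly. Against 4-chloro-2-(trifluoromethyl)phenyl the same group gives a 1.1-fold lower number from compound 1 to compound 3 (0.03 log units; within the scatter) and so shows that these two placements of chloro and trifluoromethyl cannot be told apart here. Nothing available explains either step. The compounds shown leave open whether this position tolerates a ring without trifluoromethyl, such as plain phenyl, or one carrying a nitrile or a carboxylic acid.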